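The compounds below may be only part of what the source reports. "The series", "measured", "known", "first", "only" and "open" are said of these compounds alone.

Three compounds that share one core were tested in an ADME assay on HepG2 cells (Homo sapiens) for inhibition, with a stated time of 48 h; on this read-out lower numbers stand for an effect already at smaller amounts and higher numbers for an effect only at larger amounts of compound. Compound 1 `C[C@@H](C(=O)N1CC2CC2C1)N1CCN(S(=O)(=O)c2ccc(C(C)(C)C)cc2)CC1` gives > 40000 nM, which is a limit of the assay rather than a measured number. Compound 2 `CC(C(=O)N1CCCCC1)N1CCN(S(=O)(=O)c2ccc(C(C)(C)C)cc2)CC1` also reaches only a limit, > 40000 nM. Compound 3 `CC(C(=O)N1CCCCCC1)N1CCN(S(=O)(=O)c2ccc(C(C)(C)C)cc2)CC1` likewise gives > 40000 nM, again a limit. Compound 3 therefore stands exactly where the other two stand, with no number of its own to compare. The step that the two limits leave unreadable from compound 2 to compound 3 cannot be read, because both of its ends sit at the limit of > 40000 nM in this assay, at which 3 of the 3 values shown sit.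

Compound 4 `CC(C(=O)N1CCC2(CC1)CC2)N1CCN(S(=O)(=O)c2ccc(C(C)(C)C)cc2)CC1` differs from compound 3 in one place: a group of 8 heavy atoms (7 carbon, 1 nitrogen; one three-membered non-aromatic ring of carbon only, one six-membered non-aromatic ring with 1 hetero atom) in place of a group of 7 heavy atoms (6 carbon, 1 nitrogen; one seven-membered non-aromatic ring with 1 hetero atom), on a carbonyl carbon. For the measured compounds named here, no measured step gives a clean reading that bears on this change, since the only neighbouring step is unreadable and every value so far is a limit. The earlier ring swaps on the carbonyl carbon left each compound at the limit, and this swap is of the same kind. A step beyond the usual scatter is therefore not expected in this assay, in either direction. The step that this expectation means is estimated at a step that the limit leaves unreadable from compound 3 to compound 4. Compound 4 is estimated at 60000 nM, most likely between 20000 nM and 200000 nM, and would most probably again be reported only as a limit.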

Compound 4, half-maximal effective concentration: > 40000 nM
Compound 4: a limit, no number (the forecaster's own chance of this, stated with the estimate: 85%); the middle value is on the limit's open side.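

The steps from compound 2 to compound 4 and from compound 3 to compound 4 cannot be read, because in this assay both ends of each step sit at one and the same limit: the limit of > 40000 nM in this assay, at which 4 of the 4 values shown sit.

The compounds shown give no actual number, which leaves open how these groups on a carbonyl carbon compare with one another.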